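Trading a Nitrile for a Sulfonic Acid

A few compounds are considered here, and "the series" means these few. Any claim that something is new, unique, unknown or untested is made for them only; others in the source may bear on it.

Compound 1 `N#CCCSC(=S)NCc1cccnc1` has been tested in a functional assay on Bel-7402 cells (Homo sapiens) for cytotoxicity, read by resazurin assay, with a stated time of 72 h (a lower number here means a stronger inhibitor, a higher number a weaker inhibitor), and in this assay compound 1 gives 1030 nM. That is the only numerical result available, since the other entry is a limit rather than a number. Compound 2 `O=C(CCSC(=S)NCc1cccnc1)NCc1ccccc1` reaches only the limit of this assay, and compound 2 gives > 100000 nM. Among the measured compounds shown here, the single piece of evidence from the measured pair is therefore this: the limit of > 100000 nM in this assay, at which 1 of the 2 values shown sits. For the measured compounds named here, no two measured compounds differ in just one place, so there is no measured step to draw on.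

Compound 3 `O=S(=O)(O)CCCSC(=S)NCc1cccnc1` differs from compound 1 in one place: sulfomethyl in place of cyano on a saturated chain carbon, two bonds along the chain from a sulfur. The expected step, beyond the usual scatter and toward weaker inhibition, is given for compound 3 as a 19-fold higher number from compound 1 to compound 3 (1.29 log units; beyond the scatter). In this assay compound 3 is estimated to give 20000 nM, with a likely range from 3000 nM to 100000 nM.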

Compound 3, half-maximal inhibitory concentration: 6590 nM
Compound 3: middle estimate off by 3.0-fold (0.48 log units), on the high side; measured number inside the range.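

This step gives the position on a saturated chain carbon, two bonds along the chain from a sulfur, its first real measured change: in this assay, sulfomethyl in place of cyano brings a 6.4-fold higher number from compound 1 to compound 3 (0.81 log units; beyond the scatter), a modest step that still lies beyond the usual scatter. The swap adds heavy atoms and a hydrogen-bond donor, and compound 3 still gives a true number rather than a limit, so this position can take a change of this kind without the reading leaving the range of the assay. Nothing measured here explains why the number moves by this amount, and compound 2, whose value is only a limit, adds no explanation.

A single step cannot separate the effect of the sulfur-bearing acid group from that of the extra chain carbon that comes with it. A carboxylic acid, an amine or a longer chain at this carbon would show whether the change in number follows the acid group, the size of the new group or the length of the chain.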